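Pyrrolidin-1-yl in Place of Methylamino on Compound 2

A few compounds are considered here, and "the series" means these few. Any claim that something is new, unique, unknown or untested is made for them only; others in the source may bear on it.

Of the compounds shown here, two with a shared core have been measured so far. In a physicochemical assay for solubility, at pH 6.8 (on this read-out higher numbers stand for higher solubility and lower numbers for lower solubility), compound 1 (`CN1CCN(C(=O)c2cc3cc(Cl)cc(N)c3[nH]2)CC1`) gives 67 ug/mL, and compound 2 (`CNC1CN(C(=O)c2cc3cc(Cl)cc(C)c3[nH]2)C1`) gives 51 ug/mL. These two values lie within the scatter of each other, so compound 2 cannot be told apart from compound 1 on these numbers.

Compound 3 (`Cc1cc(Cl)cc2cc(C(=O)N3CC(N4CCCC4)C3)[nH]c12`) keeps the core of compound 2 and has not yet been measured. It carries pyrrolidin-1-yl in place of methylamino on a saturated ring carbon. Among the compounds with values here, the two measured compounds differ in more than one place, so no measured step speaks directly to this change. In this assay, no step beyond the scatter is expected, and no direction can be favoured with confidence. The expectation therefore rests on compound 2, at 51 ug/mL. The estimate amounts to a 1.1-fold lower number from compound 2 to compound 3 (0.05 log units; within the scatter), an expected change that stays within the scatter. Compound 3 is expected at 45 ug/mL, with an estimated range from 15 ug/mL to 130 ug/mL.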

Compound 3, solubility: 10 ug/mL
For compound 3 the middle estimate is 4.5-fold (0.65 log units) above the measured one, outside the stated range (below it).
By their numbers in this assay, from the lowest: compound 3; then compounds 2 and 1 (each within the scatter of the next).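

In this assay, putting pyrrolidin-1-yl in place of methylamino on a saturated ring carbon of the four-membered ring gives a 5.1-fold lower number from compound 2 to compound 3 (0.71 log units; beyond the scatter), so this position, which the two earlier compounds could not speak to, does respond to this change. The step is a single one and bundles several differences: the group that leaves has no ring and 1 hydrogen-bond donor, while the group that enters has a five-membered non-aromatic ring and 0 hydrogen-bond donors, and the numbers do not show which of these differences matters. No independent measurement bearing on this step is available to explain it.

The compounds shown leave open whether the drop follows the ring or the missing hydrogen on the nitrogen: dimethylamino, which has no ring and no such hydrogen, could land near compound 2 at 51 ug/mL or near compound 3 at 10 ug/mL. Going by these compounds, it is also open whether a ring amine carrying a further hetero atom, such as morpholin-4-yl, would behave like pyrrolidin-1-yl at this position.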